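Swapping Nitro for Chloro in Compound 3

A few compounds are considered here, and "the series" means these few. Any claim that something is new, unique, unknown or untested is made for them only; others in the source may bear on it.

Measured so far in a functional assay on HepG2 cells (Homo sapiens) for cytotoxicity, read by MTT assay, with a stated time of 24 h (on this read-out higher numbers stand for weaker inhibition and lower numbers for stronger inhibition), are three compounds:

compound 1 `O=C1/C(=C/c2cccnc2)CN(S(=O)(=O)c2ccc(Cl)cc2)C/C1=C\c1ccccc1C(F)(F)F` gives 3620 nM
compound 2 `Cc1ccc(S(=O)(=O)N2C/C(=C\c3ccncc3)C(=O)/C(=C/c3ccccc3C(F)(F)F)C2)cc1` gives 4640 nM
compound 3 `O=C1/C(=C/c2ccncc2)CN(S(=O)(=O)c2ccc([N+](=O)[O-])cc2)C/C1=C\c1ccccc1C(F)(F)F` gives 13400 nM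

For the measured compounds named here, of these three numbers, the one for compound 3 is the highest, and the other two lie below it by more than the scatter. The next compound to be tested is compound 4 `O=C1/C(=C/c2ccncc2)CN(S(=O)(=O)c2ccc(Cl)cc2)C/C1=C\c1ccccc1C(F)(F)F`, which keeps the rest of compound 3 and alters one substituent. The difference is chloro in place of nitro on an aromatic carbon, so that 4-nitrophenyl becomes 4-chlorophenyl.

Going by the values given here, no nitro-to-chloro step has been measured. The nearest evidence is a 2.9-fold higher number from compound 2 to compound 3 (0.46 log units; beyond the scatter), a modest change with nitro in place of methyl on an aromatic carbon. Compound 1 already carries the (4-chlorophenyl)sulfonyl group and gives 3620 nM, although it differs from compound 4 elsewhere in the structure. On these two grounds, a modest step toward a lower number is expected in this assay, and the estimate is a 3.2-fold lower number from compound 3 to compound 4 (0.50 log units; beyond the scatter) for this change. For compound 4 the estimated value is 4200 nM, with an expected range from 2000 nM to 9000 nM.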

Compound 4, half-maximal inhibitory concentration: 7190 nM
Estimate against measurement, compound 4: 1.7-fold (0.23 log units) below; low and high end bracket the measured number.
By their numbers in this assay, from the lowest: compounds 1, 2, 4 and 3 (each within the scatter of the next, the first and the last beyond it).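

In this assay, the change from nitro to chloro on the aromatic carbon gives a 1.9-fold lower number from compound 3 to compound 4 (0.27 log units; within the scatter), so this swap at the position para to a large group cannot be told apart from repeat measurement. Replacing methyl with chloro at the same place gives a 1.5-fold higher number from compound 2 to compound 4 (0.19 log units; within the scatter), even though replacing methyl with nitro gives a 2.9-fold higher number from compound 2 to compound 3 (0.46 log units; beyond the scatter), which places the chloro compound within the scatter of both neighbours while those two remain distinct. The first comparison at the other varied place, pyridin-4-yl for pyridin-3-yl with the (4-chlorophenyl)sulfonyl group held constant, gives a 2.0-fold higher number from compound 1 to compound 4 (0.30 log units; within the scatter), and nothing shown accounts for any of these steps.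

All three new steps lie within the scatter. The compounds shown do not settle whether the aromatic substituent or the pyridine attachment has any real bearing on the read-out beyond the single separation between methyl and nitro. They also leave open what an amine, a methoxy group or a carboxylic acid would give on that aromatic carbon, and whether the pyridin-3-yl and pyridin-4-yl comparison would read the same with methyl or nitro in place of chloro.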